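Racemic carbamate versus its S enantiomer in the series

A few compounds are considered here, and "the series" means these few. Any claim that something is new, unique, unknown or untested is made for them only; others in the source may bear on it.

Measured in a functional assay on CHO cells for antagonist activity at metabotropic glutamate receptor 5 (Homo sapiens), read by calcium flux; a higher number here means a weaker inhibitor, a lower number a stronger inhibitor; every value returned is a limit of the assay, not a number.
- compound 1, `Cc1c(COC(=O)Nc2ccccc2)sc2ncnn12`: > 31600 nM
- compound 2, `Cc1c(C(C)OC(=O)N(C)c2ccccc2)sc2ncnn12`: > 31600 nM
- compound 3, `Cc1c([C@H](C)OC(=O)Nc2ccccc2)sc2ncnn12`: > 10000 nM

Compound 3 sits at the limit of > 10000 nM in this assay, at which 1 of the 3 values shown sits. The other two compounds sit at the limit of > 31600 nM in this assay, at which 2 of the 3 values shown sit. Going by the values given here, no compound in the set has a readable number, so there is no ranking among them; the single measured change, a step that the two limits leave unreadable from compound 1 to compound 3, is left unreadable by the two limits.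

Compound 4, `Cc1c(C(C)OC(=O)Nc2ccccc2)sc2ncnn12`, is the next compound. It differs from compound 3 only in this way: the two compounds have the same atoms and bonds; at least one stereo element is drawn with a configuration in one of them and without one in the other: 1 of 1 stereo elements differ; a stereocentre at a saturated chain carbon is drawn S in compound 3 and without a configuration in compound 4. In words, the two share all atoms and bonds, and the stereocentre at the saturated chain carbon drawn S in compound 3 is drawn without a configuration in compound 4.

Among the compounds with values here, no measured step bears on the loss of a drawn configuration, and the one measured step gives no size to carry over. The only anchor is the limit returned by compound 3. Compound 4 is therefore expected to give 30000 nM, with a range from 10000 nM to 100000 nM. The step from compound 3 to compound 4 is estimated as a step that the limit leaves unreadable from compound 3 to compound 4, meaning no change beyond the scatter is expected, with a limit rather than a number the most likely outcome.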

Compound 4, half-maximal inhibitory concentration: > 31600 nM
Compound 4 ended at the assay's limit (the forecaster's own chance of this, stated with the estimate: 85%); middle value at least 1.0-fold (0.02 log units) away from the limit.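

In this assay compound 4 gives > 31600 nM, a limit of the assay and not a number. Its steps from compounds 1, 2 and 3 all join two limits, so none can be read. The compounds shown leave open whether the S configuration, the chain methyl or the nitrogen methyl changes inhibition at all.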